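A few compounds are considered here, and "the series" means these few. Any claim that something is new, unique, unknown or untested is made for them only; others in the source may bear on it.

For the measured compounds named here, in a functional assay on HepG2 cells (Homo sapiens) for inhibition, read by fluorescence and resazurin assay, with a stated time of 72 h (on this read-out lower numbers stand for stronger inhibition and higher numbers for weaker inhibition), compound 1 `O=C(Nc1ccccc1)Nc1cccc(Nc2nccc(Nc3ccc4cn[nH]c4c3)n2)c1` gives 8200 nM and compound 2 `O=C(Nc1ccccc1)Nc1cccc(Nc2nccc(Nc3ccc4[nH]ncc4c3)n2)c1` gives 8100 nM on the same read-out, so compound 2 stands level with the only other number available. The next structure, compound 3 `O=C(Nc1ccccc1)Nc1cccc(Nc2nccc(Nc3ccc4[nH]ccc4c3)n2)c1`, has 1H-indol-5-yl in place of 1H-indazol-5-yl on a nitrogen on an aromatic ring, and the exchange counts as 1H-indol-5-yl in place of 1H-indazol-5-yl on a nitrogen on an aromatic ring in full. The only measured step, a 1.0-fold lower number from compound 1 to compound 2 (0.01 log units; within the scatter) as shown, alters the same indazolyl group but keeps its ring atoms, so it bears on this change only loosely. Going by the values given here, no measured compound yet carries the 1H-indol-5-yl group. With so little evidence, no step beyond the scatter is expected in this assay here. The estimated change is a 1.1-fold lower number from compound 2 to compound 3 (0.03 log units; within the scatter) and remains within that scatter. Compound 3 is expected at 7500 nM with an estimated range from 3500 nM to 16000 nM in this measurement.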

Compound 3, half-maximal inhibitory concentration: 5000 nM
Beside the measured number, compound 3's estimate is 1.5-fold (0.18 log units) above it; measured number inside the range.
By their numbers in this assay, from the lowest: compounds 3, 2 and 1 (each within the scatter of the next).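

In this assay, 1H-indol-5-yl in place of 1H-indazol-5-yl gives a 1.6-fold lower number from compound 2 to compound 3 (0.21 log units; within the scatter), and 1H-indol-5-yl in place of 1H-indazol-6-yl gives a 1.6-fold lower number from compound 1 to compound 3 (0.21 log units; within the scatter). Unlike the earlier step, which kept the ring atoms of the indazolyl group, these exchanges alter them: a ring nitrogen gives way to carbon and the entering group counts no hydrogen-bond acceptor, yet on this nitrogen on an aromatic ring the number stays within the scatter. Nothing available explains this outcome.

The compounds shown leave open what a group without the fused five-membered ring, such as plain phenyl or pyridinyl, would give at this place. They also say nothing on how the number answers to a change elsewhere on the shared core, such as an added amine or carboxylic acid.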